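The source may report more compounds than this note shows. Statements on the series, on what has been measured and on what is new or still open speak of the compounds shown alone.

Among the measured compounds shown here, in a physicochemical assay for lipophilicity, measured as octanol-water partition, at pH 7.4 (a higher number here means a more lipophilic compound, a lower number a more polar compound), compound 3 (`Cc1ccc(Cn2c(=O)[nH]c3c(N)nc(C(F)(F)F)cc32)nn1`) stands lowest of the three measured so far at 1.1 against compound 1 (`Cc1ccc(Cn2c(=O)[nH]c3c(N)nc(-c4ncco4)cc32)cn1`) at 1.6 and compound 2 (`Cc1ccc(Cn2c(=O)[nH]c3c(N)nc(C(F)(F)F)cc32)cn1`) at 2.3 in the same measurement. Compound 4 (`Cc1cccc(Cn2c(=O)[nH]c3c(N)nc(C(F)(F)F)cc32)n1`) is still unmeasured and differs from compound 3 in one group (6-methylpyridin-2-yl in place of 6-methylpyridazin-3-yl on a saturated chain carbon bound to an aromatic nitrogen). The modest step (a number 0.70 log units higher from compound 1 to compound 2 (beyond the scatter)) lies at another place and says little here. The large step at this same place (a number 1.20 log units lower from compound 2 to compound 3 (beyond the scatter)) brought in 6-methylpyridazin-3-yl for 6-methylpyridin-3-yl. Compound 4 swaps that group out again for 6-methylpyridin-2-yl, so a large rise of similar size is expected in this assay as well. The expected change is a number 1.20 log units higher from compound 3 to compound 4 (beyond the scatter) in size. For compound 4 the estimated value is 2.3 within a range of 1.9 to 2.7 overall.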

Compound 4, distribution coefficient: 2.3
Compound 4: the middle estimate sits on the measured number at the digits printed; the range from low to high includes it.
By their numbers in this assay, from the lowest: compound 3; then compound 1; then compounds 2 and 4 (each within the scatter of the next).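

In this assay, 6-methylpyridin-2-yl in place of 6-methylpyridazin-3-yl gives (a number 1.20 log units higher from compound 3 to compound 4 (beyond the scatter)), so the low number of compound 3 does not return with this second pyridine group. Among the compounds shown here, the two methylpyridine groups read alike (no change at the digits printed from compound 2 to compound 4 (within the scatter)), leaving 6-methylpyridazin-3-yl, the one group here with two ring nitrogens, apart from both. Nothing shown explains why these groups differ. Still open, going by these compounds, is how a phenyl ring or a carboxylic acid would read at this place, and whether these gaps hold with 1,3-oxazol-2-yl instead of trifluoromethyl on the core.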